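Removing one ring bromo: compound 3 to compound 4

This account rests on a few compounds, and the source may have more. Where it says the series, first, only, none or still open, it means among the compounds named here.

Measured so far in this series:
compound 1 `COc1cc(/C=N/Nc2nc(-c3ccc(Br)cc3)cs2)cc(Br)c1OC` — 64600 nM
compound 2 `COc1cc(/C=N/Nc2nc(-c3ccc(F)c(F)c3)cs2)cc(Br)c1OC` — 22400 nM
compound 3 `COc1cc(/C=N/Nc2nc(-c3ccccc3)cs2)c(Br)c(Br)c1OC` — 33600 nM

In a functional assay on HepG2 cells (Homo sapiens) for inhibition, read by MTT assay, with a stated time of 48 h (on this read-out lower numbers stand for stronger inhibition and higher numbers for weaker inhibition), compound 1 gives 64600 nM, compound 2 gives 22400 nM and compound 3 gives 33600 nM. Compound 3 sits close to both others: its gap to compound 2 and its gap to compound 1 each stay within the scatter, so the three numbers cannot be ranked against one another with any confidence.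

Within the data shown here, the only single-point step measured is a 2.9-fold lower number from compound 1 to compound 2 (0.46 log units; beyond the scatter), a modest move that concerns the aryl group on the thiazole side of the shared core, not the hydrazone side.

Compound 4 `COc1cc(/C=N/Nc2nc(-c3ccccc3)cs2)cc(Br)c1OC` differs from compound 3 by hydrogen in place of bromo on an aromatic carbon; the site is ortho to a bromo group, meta to a methoxy group and para to a methoxy group, and only the hydrogen atom enters. Among the measured compounds shown here, no measured step touches this ring, so the step from compound 1 to compound 2 gives no direct guide, and the three values together leave the series flat. With nothing pointing in either direction, the change from compound 3 to compound 4 is expected to fall within the scatter, as a 1.1-fold lower number from compound 3 to compound 4 (0.05 log units; within the scatter). Compound 4 is therefore estimated at 30000 nM, with a range of 10000 nM to 90000 nM in this assay.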

Compound 4, half-maximal inhibitory concentration: 68300 nM
For compound 4 the middle estimate is 2.3-fold (0.36 log units) below the measured one, and the stated range covers the measured number.
By their numbers in this assay, from the lowest: compounds 2, 3, 1 and 4 (each within the scatter of the next, the first and the last beyond it).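

In this assay, among these compounds, the bromo on the methoxy-bearing ring, at the site ortho to a bromo group and para to a methoxy group, is replaced by hydrogen with a 2.0-fold higher number from compound 3 to compound 4 (0.31 log units; beyond the scatter), the first measured step on this ring; it shows that this site is not silent, although the step is modest. On the aryl group at the other end of the shared core, the same exchange of bromo for hydrogen gives a 1.1-fold higher number from compound 1 to compound 4 (0.02 log units; within the scatter), so it cannot be read there, whereas phenyl in place of 3,4-difluorophenyl gives a 3.0-fold higher number from compound 2 to compound 4 (0.48 log units; beyond the scatter), which shows that this end also responds to substitution in this assay. Nothing measured accounts for either step.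

Open, going by these compounds, is whether the bromo at this site is the only substituent that holds the lower number, or whether chloro, hydroxyl or an amine there would do the same. Also open, on these data alone, is whether the steps at the two ends add up when the second ring bromo and the 3,4-difluorophenyl group stand in one molecule.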